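A few compounds are considered here, and "the series" means these few. Any claim that something is new, unique, unknown or untested is made for them only; others in the source may bear on it.

Compound 3 `Cc1ccc(-c2nnc(S(C)(=O)=O)n2C)cc1` and compound 2 `CSc1nnc(-c2ccc(C)cc2)n1C` share one core. In a functional assay on the whole organism for antagonist activity, with Mus musculus as the target (on this read-out lower numbers stand for an effect already at smaller amounts and higher numbers for an effect only at larger amounts of compound), compound 3 reaches only the limit > 200 mg/kg. In this assay compound 2 reaches only the limit > 100 mg/kg. The change between them, (methylsulfanyl in place of methylsulfonyl on an aromatic carbon), yields a step that the two limits leave unreadable from compound 3 to compound 2; the values sit at the limit of > 200 mg/kg in this assay, at which 2 of the 3 values shown sit, and at the limit of > 100 mg/kg in this assay, at which 1 of the 3 values shown sits. Compound 1 `Cn1c(-c2cccc(F)c2)nnc1S(C)(=O)=O` carries another core, and the difference between the two cores is not broken down here. In this assay compound 1 reaches only the limit > 200 mg/kg. Compound 4 `CSc1nnc(-c2cccc(F)c2)n1C` arises from compound 1 by the same change, (methylsulfanyl in place of methylsulfonyl on an aromatic carbon). Because a step that the two limits leave unreadable from compound 3 to compound 2 has no readable size, the expected step of a number no higher from compound 1 to compound 4 (the limit leaves the size open) is set close to nothing. Compound 4 is therefore expected to give about 200 mg/kg, between 100 mg/kg and 400 mg/kg, most likely again only as a limit.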

Compound 4, dose for half-maximal effect: > 200 mg/kg
Compound 4: no number, only a limit; the forecaster's own chance of this, stated with the estimate: 85%; the middle value lies on the limit itself.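

Going by these compounds alone, compound 1 and compound 4 both give only limits, so no step between them can be read. Whether methylsulfanyl in place of methylsulfonyl changes the dose needed in this assay stays open: none of the compounds shown gives an actual number.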